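This account rests on a few compounds, and the source may have more. Where it says the series, first, only, none or still open, it means among the compounds named here.

Going by the values given here, compound 2 `COCCOC(=O)/C(C#N)=C/c1c(-c2ccccc2)[nH]c2ccccc12` gives 76000 nM in an ADME assay on CRL-7065 cells (Homo sapiens) for cytotoxicity, read by MTT assay, with a stated time of 96 h (on this read-out lower numbers stand for an effect already at smaller amounts and higher numbers for an effect only at larger amounts of compound), and so stands at the upper end of the two numbers known, though within the scatter of compound 1 `N#C/C(=C\c1c(-c2ccccc2)[nH]c2ccccc12)C(=O)c1cccs1`, which gives 45000 nM. Compound 3 `N#C/C(=C\c1c(-c2ccccc2)[nH]c2ccccc12)C(=O)c1ccc(Cl)cc1` carries 4-chlorophenyl in place of 2-methoxyethoxy on a carbonyl carbon. Among the compounds with values here, only one measured step bears on this change: a 1.7-fold higher number from compound 1 to compound 2 (0.23 log units; within the scatter), an exchange on the same carbonyl carbon that gave no step beyond the scatter. Accordingly no change beyond the scatter is expected, a 1.5-fold lower number from compound 2 to compound 3 (0.18 log units; within the scatter). For compound 3 the estimated value in this assay is 50000 nM, with a range from 20000 nM to 120000 nM.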

Compound 3, half-maximal effective concentration: 7400 nM
The estimate for compound 3 lay 6.8-fold (0.83 log units) above the measured number; the whole stated range lies above it.
By their numbers in this assay, from the lowest: compound 3; then compounds 1 and 2 (each within the scatter of the next).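

In this assay the carbonyl carbon turns out to be a place where an exchange can move the number beyond the scatter, which the earlier pair did not show: 4-chlorophenyl in place of 2-methoxyethoxy gives a 10-fold lower number from compound 2 to compound 3 (1.01 log units; beyond the scatter) and 4-chlorophenyl in place of thiophen-2-yl gives a 6.1-fold lower number from compound 1 to compound 3 (0.78 log units; beyond the scatter). Nothing measured here accounts for these steps. The compounds shown leave open whether the chlorine or the six-membered ring carries the change, and how an unsubstituted phenyl, a 4-methoxyphenyl or an amide on the same carbonyl carbon would read.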